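The source may hold more compounds than are shown below. What is called first, only, known or untested is meant among the compounds shown, and "the series" means these compounds.

Compound 3 `CCCCNCc1ccc(Cl)c(-c2ccccc2OC)c1` gives 360 nM in an assay on isolated protein for binding affinity to 5-hydroxytryptamine receptor 5A (Homo sapiens) (on this read-out higher numbers stand for weaker inhibition and lower numbers for stronger inhibition), and stands second highest among the three measured compounds; compound 2 `COc1ccccc1-c1cc(CN(C)C)ccc1Cl` gives 220 nM, and compound 1 `COc1ccccc1-c1cc(C2CCNC2)ccc1Cl` gives 970 nM. Compound 4 `CCCNCc1ccc(Cl)c(-c2ccccc2OC)c1` differs from compound 3 by hydrogen in place of methyl on a saturated chain carbon, three bonds along the chain from an amine nitrogen. Among the compounds with values here, only one measured step varies the amine substituent itself: a 1.6-fold higher number from compound 2 to compound 3 (0.21 log units; within the scatter), within the scatter. The other two, a 4.4-fold lower number from compound 1 to compound 2 (0.64 log units; beyond the scatter) and a 2.7-fold lower number from compound 1 to compound 3 (0.43 log units; beyond the scatter), concern the pyrrolidin-3-yl group and bear little on the shortening of a chain. Within the data shown here, with the one relevant step showing no movement beyond the scatter, no shift beyond the scatter is expected for compound 4, estimated at 360 nM, within 180 nM to 720 nM, a step of no change at the digits printed from compound 3 to compound 4 (within the scatter).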

Compound 4, inhibition constant: 120 nM
Estimate against measurement, compound 4: 3.0-fold (0.48 log units) above; measured number below the stated range.
By their numbers in this assay, from the lowest: compounds 4, 2 and 3 (each within the scatter of the next, the first and the last beyond it); then compound 1.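

In this assay, the change from butyl to propyl gives a 3.0-fold lower number from compound 3 to compound 4 (0.48 log units; beyond the scatter) and so, unlike the earlier step from dimethylamino to butylamino, shows this position responding beyond the scatter to the loss of a single methyl. Dimethylamino to propylamino gives a 1.8-fold lower number from compound 2 to compound 4 (0.26 log units; within the scatter), leaving these two amines unseparated, whereas pyrrolidin-3-yl to (propylamino)methyl gives an 8.1-fold lower number from compound 1 to compound 4 (0.91 log units; beyond the scatter) and widens the earlier gap. What the compounds shown leave open is how ethylamino or isopropylamino would compare with propylamino. No evidence at hand accounts for the step from butyl to propyl.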